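The source may report more compounds than this note shows. Statements on the series, on what has been measured and on what is new or still open speak of the compounds shown alone.

Measured so far in a functional assay on Jurkat cells (Homo sapiens); on this read-out higher numbers stand for weaker inhibition and lower numbers for stronger inhibition:
- Compound 1 `CC(C)[C@H](NC(=O)COc1cccc2ccccc12)C(=O)N[C@@H](CC(=O)O)C(=O)COc1ccc(F)cc1`: > 100000 nM (a limit of the assay, not a number)
- Compound 2 `CC(C)[C@H](NC(=O)COc1cccc2ccccc12)C(=O)N[C@@H](CC(=O)O)C(=O)COc1cc(F)cc(F)c1F`: 30000 nM

For the measured compounds named here, compound 2 holds the only actual number. The other entry is the limit of > 100000 nM in this assay, at which 1 of the 2 values shown sits.

Next is compound 3 `CC(C)[C@H](NC(=O)COc1cccc2ccccc12)C(=O)N[C@@H](CC(=O)O)C(=O)COc1cc(F)c(F)cc1F`, with 2,4,5-trifluorophenyl in place of 2,3,5-trifluorophenyl on an oxygen on a saturated carbon. In words, 2,4,5-trifluorophenyl replaces 2,3,5-trifluorophenyl on an oxygen on a saturated carbon, so the two compounds have the same atoms, joined differently.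

Going by the values given here, only one measured step bears on this: an at least 3.3-fold lower number from compound 1 to compound 2 (0.52 log units; beyond the scatter). It replaced 4-fluorophenyl with 2,3,5-trifluorophenyl, and it starts from a limit, so it gives no exact size. Among the compounds with values here, no measured step covers moving a fluorine alone.

In this assay, the expected result is a 1.3-fold higher number from compound 2 to compound 3 (0.12 log units; within the scatter), with no shift beyond the scatter anticipated in either direction. For compound 3 the estimated value is 40000 nM, with an expected range of 10000 nM to 100000 nM.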

Compound 3, half-maximal inhibitory concentration: 39300 nM
Compound 3: middle estimate off by 1.0-fold (0.01 log units), on the high side; the measured number falls inside the stated range.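

In this assay, rearranging the three fluorines gives a 1.3-fold higher number from compound 2 to compound 3 (0.12 log units; within the scatter), so at this place, on an oxygen on a saturated carbon, 2,3,5-trifluorophenyl and 2,4,5-trifluorophenyl cannot be told apart. A second trifluorophenyl group also lies beyond the scatter against 4-fluorophenyl, with an at least 2.5-fold lower number from compound 1 to compound 3 (0.40 log units; beyond the scatter), so the lower number is not confined to one arrangement of fluorines among these three compounds. That step gives a bound and no exact size, as compound 1 stands at a limit of the assay, not a number: the limit of > 100000 nM in this assay, at which 1 of the 3 values shown sits.

Going by these compounds, what a difluorophenyl or pentafluorophenyl group would give at this place stays open, so the number of fluorines cannot yet be separated from their arrangement. Also open, on these data alone, is how an unsubstituted phenyl or a chlorophenyl group would read here.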